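Chloro in Place of Fluoro: What to Expect

A few compounds are considered here, and "the series" means these few. Any claim that something is new, unique, unknown or untested is made for them only; others in the source may bear on it.

Compound 1 (`O=C(CCCCCCC(=O)Nc1cccc(F)c1)NO`) gives 1400 nM
Compound 2 (`O=C(CCCCCCC(=O)Nc1ccc(C(F)(F)F)cc1)NO`) gives 1400 nM

Within the data shown here, in a functional assay on HT-29 cells (Homo sapiens) for antiproliferative activity, with a stated time of 48 h (a lower number here means that less compound is needed, a higher number that more compound is needed for the effect), compound 1 gives 1400 nM and stands level with compound 2, the only other compound measured so far. The two values lie within the usual scatter of repeated measurements, so neither compound can be ranked above the other.

The next compound to be measured is compound 3 (`O=C(CCCCCCC(=O)Nc1cccc(Cl)c1)NO`). It has chloro in place of fluoro on an aromatic carbon, and the rest of the structure of compound 1 stays the same. Among the measured compounds shown here, no measured pair shows what this particular swap does, so any forecast here is cautious. Compound 2 carries trifluoromethyl and no fluoro, yet its 1400 nM matches the value of compound 1. In this assay the expected step is none beyond the scatter, with a slight lean towards a lower number. The expected step is a 1.2-fold lower number from compound 1 to compound 3 (0.07 log units; within the scatter) (an estimate). For compound 3 the estimated value is 1200 nM (expected range 550 nM to 2600 nM).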

Compound 3, half-maximal effective concentration: 1000 nM
For compound 3 the middle estimate is 1.2-fold (0.08 log units) above the measured one; measured number inside the range.
By their numbers in this assay, from the lowest: compounds 3, 1 and 2 (each within the scatter of the next).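

In this assay, chloro in place of fluoro on an aromatic carbon, meta to a large group, gives a 1.4-fold lower number from compound 1 to compound 3 (0.15 log units; within the scatter). Among these compounds, this is the first direct reading for this position: exchanging one of these halogens for the other, with the rest of the structure unchanged, produces no difference that can be told from the scatter. Compound 1 and compound 2 differ in more than one place and offered no such single-change reading, and nothing available here speaks to what lies behind this result.

Going by these compounds, one pair covers only a narrow change, so it remains open whether a group of another kind on the same carbon, such as methoxy, an amine or a carboxylic acid, would produce a step beyond the scatter. Among the compounds shown here, it also remains open whether chloro in place of fluoro would read the same on another carbon of this ring, or with a longer chain in place of the one shared by these compounds.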